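A few compounds are considered here, and "the series" means these few. Any claim that something is new, unique, unknown or untested is made for them only; others in the source may bear on it.

Working notes on the series. Among the measured compounds shown here, compound 2 `COc1ncc(-c2ccc3c(c2)N(c2ccc(Cl)cc2)C(=O)CO3)cc1NS(=O)(=O)c1ccc(F)cc1` is the only member that returns a number in a functional assay on HeLa cells (Homo sapiens) for antiproliferative activity, read by MTT assay, with a stated time of 72 h; on this read-out higher numbers stand for weaker inhibition and lower numbers for stronger inhibition: compound 2 gives 4830 nM. Compound 1 `O=C1COc2ccc(-c3cnc(Cl)c(NS(=O)(=O)c4ccc(F)cc4)c3)cc2N1c1ccc(Cl)cc1` returns only a limit, > 40000 nM. Compound 3 `COc1cccc(N2C(=O)COc3ccc(-c4cccc(NS(=O)(=O)c5ccc(F)cc5)c4)cc32)c1` also returns only a limit, > 40000 nM. For the measured compounds named here, the single measured step, an at least 8.2-fold lower number from compound 1 to compound 2 (0.91 log units; beyond the scatter), concerns methoxy in place of chloro on an aromatic carbon, and its size is known only as a bound because of the limit of > 40000 nM in this assay, at which 2 of the 3 values shown sit.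

Compound 4 `COc1ncc(-c2ccc3c(c2)N(c2ccccc2)C(=O)CO3)cc1NS(=O)(=O)c1ccc(F)cc1` differs from compound 2 by hydrogen in place of chloro on an aromatic carbon, a change that on the wider reading runs from 4-chlorophenyl to phenyl. Going by the values given here, no measured step touches this position; the step of an at least 8.2-fold lower number from compound 1 to compound 2 (0.91 log units; beyond the scatter) sits on a different ring, so it offers no direct guide, and compounds 1 and 3 both stand at a limit and so cannot be read as a trend. With nothing pointing either way, the expectation for compound 4 in this assay is a step of a 1.2-fold higher number from compound 2 to compound 4 (0.09 log units; within the scatter), within the scatter. Compound 4 is therefore estimated at 6000 nM, with a range from 2000 nM to 18000 nM.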

Compound 4, half-maximal inhibitory concentration: 1530 nM
For compound 4 the middle estimate is 3.9-fold (0.59 log units) above the measured one; measured number outside the range, below it.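

Among the compounds shown here, this is the first measured change on the 4-chlorophenyl group, and in this assay hydrogen in place of chloro gives a 3.2-fold lower number from compound 2 to compound 4 (0.50 log units; beyond the scatter) on this series' methoxy-bearing background. The position para to a large group therefore responds to substitution, and the chloro is not required for a measurable number in this read-out, with the phenyl form giving the lower number of the pair. Nothing in the data shown gives a reason for this step.

The compounds shown compare only chloro and hydrogen at this place, so how an amine, a carboxylic acid or a longer alkyl chain there would read stays open. Also open, from the compounds shown here alone, is whether the same change gives a step of similar size with chloro in place of the methoxy on the other ring.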